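A few compounds are considered here, and "the series" means these few. Any claim that something is new, unique, unknown or untested is made for them only; others in the source may bear on it.

Compound 3 `O=C(O)CC(CSCCCCCCc1ccc(Cl)cc1Cl)C(=O)O` holds the lowest number of the three compounds measured in an assay on isolated protein for inhibition of ATP-citrate synthase (Rattus norvegicus) (a higher number here means a weaker inhibitor, a lower number a stronger inhibitor), giving 2600 nM. Compound 2 `O=C(O)CC(O)(CSCCCCCCc1ccccc1Cl)C(=O)O` gives 69000 nM in this assay, and compound 1 `O=C(O)CC(O)(CSCCCCCCCCCc1ccc(Cl)cc1Cl)C(=O)O` gives 300000 nM, both well beyond the scatter from compound 3. Compound 4 `O=C(O)CCCSCCCCCCc1ccc(Cl)cc1Cl` is the next compound to be measured, and it differs from compound 3 by hydrogen in place of carboxy on a saturated chain carbon bound to two saturated chain carbons. Among the compounds with values here, no step between measured compounds covers this change. Removing a carboxy group from the dicarboxylic acid unit is expected to weaken inhibition in this assay substantially, with the step of a 23-fold higher number from compound 3 to compound 4 (1.36 log units; beyond the scatter) estimated to lie well beyond the scatter. Compound 4 is therefore expected to give about 60000 nM in this assay, within a range from 8000 nM to 400000 nM.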

Compound 4, inhibition constant: 25000 nM
For compound 4 the middle estimate is 2.4-fold (0.38 log units) above the measured one, and the stated range covers the measured number.
By their numbers in this assay, from the lowest: compound 3; then compound 4; then compound 2; then compound 1.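

In this assay, hydrogen in place of carboxy on a saturated chain carbon bound to two saturated chain carbons gives a 9.6-fold higher number from compound 3 to compound 4 (0.98 log units; beyond the scatter). Within the data shown here, this is the first comparison that isolates a single place, and it shows that inhibition at this position responds to the change from 1,2-dicarboxyethyl to 2-carboxyethyl. Nothing in the available evidence accounts for the size of this step. The compounds shown leave open how an amide or a hydroxyl group at this position would compare with carboxy and with hydrogen. They also leave open whether the step would keep its size with a longer chain.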